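An Ethyl Group Added to a Cytotoxic Compound

This account rests on a few compounds, and the source may have more. Where it says the series, first, only, none or still open, it means among the compounds named here.

In a functional assay on HCT-8 cells (Homo sapiens) for cytotoxicity (a lower number here means that less compound is needed, a higher number that more compound is needed for the effect), compound 1 (`COC1=C(C)C(=O)/C(=C(O)/C=C/c2cccc3ccccc23)C(=O)C1(C)C`) gives 2.3 ug/mL and compound 2 (`COC1=C(C)C(=O)/C(=C(O)/C=C/c2nccs2)C(=O)C1(C)C`) gives 5.1 ug/mL as its value. In this assay compound 3 (`COC1=CC(O)=C(C(=O)/C=C/c2ccccc2)C(=O)C1(C)C`) gives 3.3 ug/mL as its value, which lies within the usual scatter of the values of both compound 1 and compound 2.

Compound 4 (`CCC1=C(OC)C(C)(C)C(=O)C(C(=O)/C=C/c2ccccc2)=C1O`) has not yet been measured. It differs from compound 3 in one place: ethyl in place of hydrogen on a double-bonded ring carbon with ethyl in place of hydrogen on a double-bonded ring carbon, next to the ring atom that bears a hydroxy group and next to the ring atom that bears a methoxy group.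

Within the data shown here, no measured pair isolates this change, so the expectation rests on limited evidence. Compound 1 carries methyl on a double-bonded ring carbon and still gives 2.3 ug/mL as its value, within the scatter of compound 3. The expected step is a 1.1-fold lower number from compound 3 to compound 4 (0.04 log units; within the scatter) and is not expected to exceed the scatter. For compound 4 the estimate is 3 ug/mL as a middle value, with 1.3 ug/mL to 7 ug/mL as the expected range.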

Compound 4, concentration for half-maximal effect: 9.4 ug/mL
Compound 4: middle estimate off by 3.1-fold (0.50 log units), on the low side, and the stated range ends below it.
By their numbers in this assay, from the lowest: compounds 1, 3, 2 and 4 (each within the scatter of the next, the first and the last beyond it).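

In this assay, ethyl in place of hydrogen on a double-bonded ring carbon gives a 2.8-fold higher number from compound 3 to compound 4 (0.45 log units; beyond the scatter) and so shows that this position, next to the ring atom that bears a hydroxy group and next to the ring atom that bears a methoxy group, responds to substitution. Among these compounds, compound 1 and compound 2 could not show this: each differs from compound 3 in more than one place, and no earlier pair isolated the change. No measurement shown here explains the step.

A single step leaves open whether the higher number is specific to ethyl or would also appear with other groups at this position, such as a propyl chain or an amine. It also leaves open whether the same change would have a similar effect on a different shared core.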